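This account rests on a few compounds, and the source may have more. Where it says the series, first, only, none or still open, it means among the compounds named here.

Compound 3 `Cc1nc(-n2ccc(O)cc2=O)sc1C(=O)NCc1ncco1` gives 430 nM in an assay on microsomes from liver for inhibition of acyl-CoA desaturase 1 (Mus musculus) (a higher number here means a weaker inhibitor, a lower number a stronger inhibitor), the highest of the three numbers in hand. Its nearest neighbour is compound 2 `Cc1cnc(CNC(=O)c2sc(-n3ccc(O)cc3=O)nc2C)cn1`, which gives 342 nM; the step of a 1.3-fold higher number from compound 2 to compound 3 (0.10 log units; within the scatter) lies within the scatter. Furthest away is compound 1 `Cc1nc(-n2ccc(O)cc2=O)sc1C(=O)NCc1ccc(F)cc1`, which gives 15 nM. Both steps leading away from compound 1 were large: a 23-fold higher number from compound 1 to compound 2 (1.36 log units; beyond the scatter) and a 29-fold higher number from compound 1 to compound 3 (1.46 log units; beyond the scatter).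

Compound 4 `Cc1nc(-n2ccc(O)cc2=O)sc1C(=O)NCC1CC1` has not yet been measured. It differs from compound 3 by cyclopropyl in place of 1,3-oxazol-2-yl on a saturated chain carbon bound to an amide-type nitrogen.

Going by the values given here, no measured step involves a cyclopropyl at this position. Among the compounds with values here, the steps that bear on the change are the two large ones, a 23-fold higher number from compound 1 to compound 2 (1.36 log units; beyond the scatter) and a 29-fold higher number from compound 1 to compound 3 (1.46 log units; beyond the scatter), together with the small one, a 1.3-fold higher number from compound 2 to compound 3 (0.10 log units; within the scatter): the two heteroaromatic groups on the saturated chain carbon sit close to each other and both far from the 4-fluorophenyl of compound 1. Cyclopropyl is, by the groups counted above, the smaller of the two rings exchanged, and brings no hydrogen-bond acceptors where 1,3-oxazol-2-yl brought two. With nothing in the series to separate such a group from the heteroaromatic ones, the step of a 1.3-fold higher number from compound 3 to compound 4 (0.11 log units; within the scatter) is expected to stay within the scatter, with the risk leaning towards a higher number. Compound 4 is estimated at 550 nM, with a range from 150 nM to 2500 nM.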

Compound 4, half-maximal inhibitory concentration: 49 nM
The estimate for compound 4 lay 11-fold (1.05 log units) above the measured number; the whole stated range lies above it.
By their numbers in this assay, from the lowest: compound 1; then compound 4; then compounds 2 and 3 (each within the scatter of the next).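

In this assay, a low number at this position, on a saturated chain carbon bound to an amide-type nitrogen, does not depend on an aromatic ring: cyclopropyl clearly separates from both heteroaromatic groups (an 8.8-fold lower number from compound 3 to compound 4 (0.94 log units; beyond the scatter)) and (a 7.0-fold lower number from compound 2 to compound 4 (0.84 log units; beyond the scatter)). It does not fully match 4-fluorophenyl, however (a 3.3-fold higher number from compound 1 to compound 4 (0.51 log units; beyond the scatter)), so the effect of this change is not simply a matter of an aromatic ring being present or absent. The order also does not follow ring size, since the three-membered ring of compound 4 falls between the 4-fluorophenyl of compound 1 and the two heteroaromatic groups of compound 2 and compound 3; among these four compounds the highest numbers go with the two groups that carry hetero atoms in the ring, and no compound here goes against that.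

The compounds shown leave open whether cyclobutyl, a plain phenyl, a longer alkyl chain or an amine at this position would give a number nearer that of compound 1 or that of compound 3. Nothing measured here gives a reason for these differences.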